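From 1-isopropylpropyl to a fluorinated chain

A few compounds are considered here, and "the series" means these few. Any claim that something is new, unique, unknown or untested is made for them only; others in the source may bear on it.

Of the compounds shown here, three built on one shared core have been measured in a functional assay on HeLa cells (Homo sapiens) for cytotoxicity, read by WST assay, with a stated time of 48 h; a lower number here means a stronger inhibitor, a higher number a weaker inhibitor. Compound 3 (`CC[C@H](C(C)C)C(c1ccc(O)c(OC)c1)c1ccc(O)c(OC)c1`) gives 9700 nM. Compound 2 (`COc1cc(C(c2ccc(O)c(OC)c2)[C@@H](C)C(C)C)ccc1O`) gives 19000 nM. The two sit together at the low end of the numbers, since a 2.0-fold lower number from compound 2 to compound 3 (0.29 log units; within the scatter). Compound 1 (`COC[C@H](C)[C@H](C)C(c1ccc(O)c(OC)c1)c1ccc(O)c(OC)c1`) gives 72000 nM and stands clearly apart from both.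

Compound 4 (`COc1cc(C(c2ccc(O)c(OC)c2)[C@H](C)[C@@H](C)CF)ccc1O`) carries 2-(fluoromethyl)-1-methylpropyl in place of the 1-isopropylpropyl of compound 3, on a saturated chain carbon bound to two aromatic carbons: 2-(fluoromethyl)-1-methylpropyl in place of 1-isopropylpropyl on a saturated chain carbon bound to two aromatic carbons. For the measured compounds named here, no measured step introduces fluorine, so the data offer no direct guide. The closest one is the 2-(methoxymethyl)-1-methylpropyl chain of compound 1, whose name differs from the entering group only in methoxymethyl against fluoromethyl. Leaving that chain gave modest steps: a 3.8-fold lower number from compound 1 to compound 2 (0.58 log units; beyond the scatter), and a 7.4-fold lower number from compound 1 to compound 3 (0.87 log units; beyond the scatter). A modest rise in this assay is therefore expected, smaller than the full size of the step to compound 3, which places the new chain partway back towards compound 1. The expected step is a 2.6-fold higher number from compound 3 to compound 4 (0.41 log units; beyond the scatter). Compound 4 is estimated at 25000 nM, with an expected range of 9000 nM to 70000 nM.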

Compound 4, half-maximal inhibitory concentration: 34000 nM
The estimate for compound 4 lay 1.4-fold (0.13 log units) below the measured number; the range from low to high includes it.
By their numbers in this assay, from the lowest: compounds 3, 2 and 4 (each within the scatter of the next, the first and the last beyond it); then compound 1.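

In this assay, fluorine at this position does not match the 1-isopropylpropyl chain: there is a 3.5-fold higher number from compound 3 to compound 4 (0.54 log units; beyond the scatter) when 2-(fluoromethyl)-1-methylpropyl enters on the saturated chain carbon bound to two aromatic carbons. The fluorinated chain also gives a different number from the 2-(methoxymethyl)-1-methylpropyl chain, with a 2.1-fold lower number from compound 1 to compound 4 (0.33 log units; beyond the scatter) on exchanging methoxymethyl for fluoromethyl, so the two chains with similar names are not interchangeable here. Compared with 1,2-dimethylpropyl, the printed step is a 1.8-fold higher number from compound 2 to compound 4 (0.25 log units; within the scatter) and the two compounds cannot be told apart, which means that fluoromethyl in place of a methyl of that chain has no resolved effect on the number.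

No measurement shown accounts for these differences between the chains. The compounds shown also leave open how this position would respond to a hydroxymethyl group, an amine, a carboxylic acid or a longer chain, and whether any of these would give a number lower than that of compound 3, which is 9700 nM in this assay.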